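A few compounds are considered here, and "the series" means these few. Any claim that something is new, unique, unknown or untested is made for them only; others in the source may bear on it.

In an ADME assay on Vero cells (Chlorocebus sabaeus) for cytotoxicity, read by MTT assay, with a stated time of 72 h (on this read-out lower numbers stand for an effect already at smaller amounts and higher numbers for an effect only at larger amounts of compound), compound 3 (`O=C(Nc1nc(-c2ccccn2)cs1)c1ccccc1Cl`) reads 2000 nM and so lies within the scatter of compound 2 (`COc1cccc(C(=O)Nc2nc(-c3ccccn3)cs2)c1`) at 2800 nM while both stand clearly under compound 1 (`O=C(Nc1nc(-c2ccccn2)cs1)c1cccc(OCc2ccccc2)c1`) at 14400 nM on the same scale. Compound 4 (`O=C(Nc1nc(-c2ccccn2)cs1)c1cccc(Cl)c1`) has the same atoms as compound 3, with 3-chlorophenyl in place of 2-chlorophenyl on a carbonyl carbon. Within the data shown here, only one measured step exists (a 5.1-fold lower number from compound 1 to compound 2 (0.71 log units; beyond the scatter)) and it concerns a different change, hydrogen in place of phenyl on a saturated chain carbon bound to an oxygen on an aromatic ring. Among the measured compounds shown here, it therefore bears only loosely on this comparison, and no measured step moves a chlorine. With compound 2 at 2800 nM and compound 3 at 2000 nM lying within the scatter of each other, no step beyond the scatter is expected in this assay for this change. The estimated step (a 1.3-fold higher number from compound 3 to compound 4 (0.10 log units; within the scatter)) stays small. For compound 4 the expected value is 2500 nM with an estimated range from 1100 nM to 6000 nM on this read-out.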

Compound 4, half-maximal effective concentration: 7000 nM
Compound 4: the middle estimate sits 2.8-fold (0.45 log units) below what was measured; measured number above the stated range.
By their numbers in this assay, from the lowest: compounds 3 and 2 (each within the scatter of the next); then compound 4; then compound 1.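

In this assay, among these compounds, the place of the chlorine on the ring bound to the carbonyl carbon matters: 3-chlorophenyl in place of 2-chlorophenyl gives a step beyond the scatter (a 3.5-fold higher number from compound 3 to compound 4 (0.54 log units; beyond the scatter)), the only step here that moves a chlorine and changes nothing else. Compound 4 also stands apart from the compounds carrying other groups, with chloro in place of methoxy on an aromatic carbon (a 2.5-fold higher number from compound 2 to compound 4 (0.40 log units; beyond the scatter)) and chloro in place of benzyloxy on an aromatic carbon (a 2.1-fold lower number from compound 1 to compound 4 (0.31 log units; beyond the scatter)). Nothing given here explains why these numbers differ.

As far as these compounds go, it remains open how an amine or a carboxylic acid on this ring would read in place of the chlorine. From the compounds shown here alone, it is equally open whether moving a methoxy group in the same way would produce a step of similar size.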